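The source may report more compounds than this note shows. Statements on the series, on what has been measured and on what is new or still open speak of the compounds shown alone.

Of the compounds shown here, three that share one core have so far been tested in a functional assay on RXF 393 cells (Homo sapiens) for inhibition; on this read-out lower numbers stand for stronger inhibition of growth and higher numbers for weaker inhibition of growth. Compound 1 `COc1cc(/C=C/C(=O)c2cccc(-n3cc(-c4ccccc4)[nH]c3=O)c2)ccc1O` gives 2270 nM, compound 2 `O=C(/C=C/c1cccc(O)c1)c1cccc(-n2cc(-c3ccccc3)[nH]c2=O)c1` gives 1890 nM, and compound 3 `COc1cc(/C=C/C(=O)c2cccc(-n3cc(-c4ccccc4)[nH]c3=O)c2)cc(OC)c1OC` gives 1710 nM. These numbers lie close together: compound 3 sits within the scatter of both compound 2 and compound 1, so none of the three can be set apart from the others. Going by the values given here, the one single-point step available, a 1.2-fold lower number from compound 1 to compound 2 (0.08 log units; within the scatter), alters the group on the double-bonded chain carbon and stays within the scatter. Compound 4 `COc1cc(/C=C/C(=O)c2cccc(-n3cc(-c4cc(OC)c(OC)c(OC)c4)[nH]c3=O)c2)cc(OC)c1OC` alters a different place: 3,4,5-trimethoxyphenyl in place of phenyl on an aromatic carbon. Among the compounds with values here, no measured step touches this position, so nothing shows how it will behave; with the other comparisons all small, the expected step is a 1.0-fold lower number from compound 3 to compound 4 (0.00 log units; within the scatter). Compound 4 is therefore estimated at 1700 nM in this assay, with a range from 500 nM to 6000 nM.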

Compound 4, concentration for 50% growth inhibition: 1620 nM
Compound 4: middle estimate off by 1.0-fold (0.02 log units), on the high side; low and high end bracket the measured number.
By their numbers in this assay, from the lowest: compounds 4, 3, 2 and 1 (each within the scatter of the next).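

Placing 3,4,5-trimethoxyphenyl in place of phenyl on the aromatic carbon gives a 1.1-fold lower number from compound 3 to compound 4 (0.02 log units; within the scatter) in this assay. Going by these compounds alone, this position, not varied among the earlier compounds, therefore carries a group of 12 heavy atoms with 3 hydrogen-bond acceptors, instead of 6 heavy atoms with none, without a change that can be told from scatter. No supporting data offer an explanation for this result.

Only these two groups are shown at this position. Going by these compounds, how an amine or a carboxylic acid would behave there remains open.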